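Pyrrolidine in Place of Hydroxyazetidine on a Bcl-2 Binder

The source may hold more compounds than are shown below. What is called first, only, known or untested is meant among the compounds shown, and "the series" means these compounds.

Compound 1, with the structure `Cc1c(C(=O)O)c(-c2cccc(N3CCN(c4ccc(NS(=O)(=O)c5ccc(N[C@H](CCN6CC(O)C6)CSc6ccccc6)c(S(=O)(=O)C(F)(F)F)c5)cc4)CC3)c2)c(-c2ccc(Cl)cc2)n1C`, is the stronger of the two measured compounds. In an assay for binding affinity to Apoptosis regulator Bcl-2 (Homo sapiens), read by fluorescence polarization, with a stated time of 2 h (a lower number here means a stronger inhibitor, a higher number a weaker inhibitor), compound 1 gives 1.7 nM. Compound 2, built on the same core but with an amide in place of the carboxylic acid and a different sulfonamide aryl portion, has the structure `Cc1c(C(=O)NCCCN2CCN(C)CC2)c(-c2cccc(N3CCN(c4ccc(NS(=O)(=O)c5cccc(OC(C)C)c5)cc4)CC3)c2)c(-c2ccc(Cl)cc2)n1C`; in this assay compound 2 gives 522 nM, a gap to compound 1 that lies well beyond the usual scatter. Compound 2 differs from compound 1 in several places at once. Nothing can be read from that pair about any single change.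

Compound 3, with the structure `Cc1c(C(=O)O)c(-c2cccc(N3CCN(c4ccc(NS(=O)(=O)c5ccc(N[C@H](CCN6CCCC6)CSc6ccccc6)c(S(=O)(=O)C(F)(F)F)c5)cc4)CC3)c2)c(-c2ccc(Cl)cc2)n1C`, has not yet been measured. It differs from compound 1 in one spot only: pyrrolidin-1-yl in place of 3-hydroxyazetidin-1-yl on a saturated chain carbon, three bonds along the chain from a nitrogen on an aromatic ring. Both rings carry the same number of heavy atoms, and the change sits on a saturated chain carbon far from the acid and the sulfonamide. For the measured compounds named here, no measured pair isolates this change, so the expected step from compound 1 to compound 3 is small, with no clear direction; he estimates it as a 1.2-fold higher number from compound 1 to compound 3 (0.07 log units; within the scatter), within the scatter. Compound 3 is accordingly expected to give about 2 nM, in a range from 0.8 nM to 6 nM.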

Compound 3, inhibition constant: 1.8 nM
The estimate for compound 3 lay 1.1-fold (0.05 log units) above the measured number; the range from low to high includes it.
By their numbers in this assay, from the lowest: compounds 1 and 3 (each within the scatter of the next); then compound 2.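

Pyrrolidin-1-yl in place of 3-hydroxyazetidin-1-yl on a saturated chain carbon, three bonds along the chain from a nitrogen on an aromatic ring, gives a 1.1-fold higher number from compound 1 to compound 3 (0.02 log units; within the scatter) in this assay, and this is the only step shown that isolates a single change. At this position, then, a four-membered ring carrying an oxygen and a hydrogen-bond donor and a five-membered ring with neither read alike, something the pair of compound 1 and compound 2 could not show, as those two differ in several places at once. Nothing measured here accounts for this likeness.

The compounds shown leave open whether the same holds for other groups at this position, such as a morpholine ring, a dimethylamino group or a carboxylic acid, or for a longer chain carrying the pyrrolidin-1-yl ring. They also leave open what the carboxylic acid on the shared core contributes on its own, which would take a compound differing from compound 1 in that one place, such as its methyl ester.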